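An Octylsulfanyl Chain Enters the Core of Compound 1

The compounds below may be only part of what the source reports. "The series", "measured", "known", "first", "only" and "open" are said of these compounds alone.

Compound 1 `Nc1nc(NC2CC2)c2ncn(/C=C3/CC3(CO)CO)c2n1` was tested in an ADME assay on BCBL1 cells (Homo sapiens) for cytotoxicity, with a stated time of 7 days (on this read-out lower numbers stand for higher toxicity in this test and higher numbers for lower toxicity in this test), where compound 1 gives 71500 nM. Of the two values in this assay that are numbers, compound 1 stands highest; its nearest neighbour is compound 3 `Nc1nc(NCc2ccccc2)c2ncn(/C=C3/CC3(CO)CO)c2n1`, which in this assay gives 19900 nM. Compound 2 `CC(C)CNc1nc(N)nc2c1ncn2/C=C1/CC1(CO)CO` gives only a limit of the assay, > 20000 nM. That limit, (the limit of > 20000 nM in this assay, at which 1 of the 3 values shown sits), leaves the step that the limit leaves unreadable from compound 1 to compound 2 unreadable, and the comparison a number no higher from compound 2 to compound 3 (the limit leaves the size open) stays open for the same reason. Among the compounds with values here, the one readable step is a 3.6-fold lower number from compound 1 to compound 3 (0.56 log units; beyond the scatter), benzyl in place of cyclopropyl on a nitrogen on an aromatic ring.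

Compound 4 `CCCCCCCCSc1nc(N)nc2c1ncn2/C=C1/CC1(CO)CO` differs from compound 1 in another way: octylsulfanyl in place of cyclopropylamino on an aromatic carbon. Both measured changes kept the nitrogen and replaced only the cyclopropyl on it, whereas in compound 4 the cyclopropylamino leaves entirely and an octylsulfanyl chain enters on the aromatic carbon. Within the data shown here, the single readable precedent points to a lower number, so compound 4 is expected to show a step of a 2.9-fold lower number from compound 1 to compound 4 (0.46 log units; beyond the scatter), a modest move toward higher toxicity. The estimate for compound 4 in this assay is 25000 nM, with a range from 8000 nM to 80000 nM.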

Compound 4, half-maximal cytotoxic concentration: > 20000 nM
Compound 4 gave a limit, no number; the forecaster's own chance of this, stated with the estimate: 30%; the middle value is on the limit's open side.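

In this assay, compound 4 is the first compound shown with sulfur rather than nitrogen attached to this aromatic carbon, and its result is a limit of the assay, not a number. Octylsulfanyl in place of benzylamino gives a number no lower from compound 3 to compound 4 (the limit leaves the size open), so this change at the position does not take the read-out below that of the benzylamino compound. The steps to compound 4 from compound 1 and from compound 2 cannot be read, and the limit now recurs among the values shown: the limit of > 20000 nM in this assay, at which 2 of the 4 values shown sit.

From the compounds shown here alone, it remains open whether octylsulfanyl at this position differs at all from cyclopropylamino in compound 1, which gives 71500 nM. An octylamino group on the same aromatic carbon would keep the chain while restoring the nitrogen, and a methylsulfanyl group would keep the sulfur with a much shorter chain, so these two groups would separate the part played by the linking atom from that of the chain.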